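The compounds below may be only part of what the source reports. "The series", "measured", "known", "first", "only" and "open" are said of these compounds alone.

The measured compounds:
Compound 1, `COc1ccc(-c2cc(/C=C/C(=O)c3ccc(OC)c(OC)c3)[nH]n2)cc1`, in a functional assay on HOP-62 cells (Homo sapiens) for inhibition, read by sulforhodamine B assay, with a stated time of 48 h (on this read-out higher numbers stand for lower toxicity in this test and lower numbers for higher toxicity in this test), gives 35300 nM.
Compound 2, `COc1cc(-c2cc(/C=C/C(=O)c3ccc(Cl)c(Cl)c3)[nH]n2)cc(OC)c1OC`, in this assay gives 42600 nM.

Compound 2 holds the higher of the two numbers, yet compound 1 lies so close that the two are within the scatter of repeated measurements and cannot be ordered. Compound 3, `COc1cc(-c2cc(/C=C/C(=O)c3ccc(F)c(F)c3)[nH]n2)cc(OC)c1OC`, has not yet been measured in this assay. It differs from compound 2 in one place: 3,4-difluorophenyl in place of 3,4-dichlorophenyl on a carbonyl carbon. Within the data shown here, no pair of measured compounds differs in this way, so nothing measured here tells the size or direction of such a change. The step that this estimate means, a 1.2-fold higher number from compound 2 to compound 3 (0.07 log units; within the scatter), is expected to lie within the scatter, with no direction beyond it. Compound 3 is estimated to give 50000 nM in this assay, with an expected range from 20000 nM to 120000 nM.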

Compound 3, concentration lethal to 50% of the cells: > 100000 nM
Compound 3 gave a limit, no number (the forecaster's own chance of this, stated with the estimate: 10%); middle value at least 2.0-fold (0.30 log units) away from the limit.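

Among these compounds, at the place on the carbonyl carbon, 3,4-difluorophenyl in place of 3,4-dichlorophenyl gives the only readable step in this assay, an at least 2.3-fold higher number from compound 2 to compound 3 (0.37 log units; beyond the scatter), so the choice between these two groups at this position does change the read-out, in the direction of lower toxicity in this test. Compound 3 gives > 100000 nM, which is a limit of the assay and not a number. The step therefore fixes a direction and a smallest size, but not a full size: the limit of > 100000 nM in this assay, at which 1 of the 3 values shown sits.

Compound 1 differs from compound 2 in more than one place, so it cannot show whether this change would act the same way on another version of the core. Also open, going by these compounds, is how a phenyl carrying bromine, an amine or a carboxylic acid would behave on the same carbonyl carbon.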